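The source may report more compounds than this note shows. Statements on the series, on what has been measured and on what is new or still open speak of the compounds shown alone.

In a physicochemical assay for solubility, using the shake flask method, in simulated intestinal fluid, measured as kinetic solubility, with a stated time of 2 h, at 25 degrees C, at pH 6.5 (on this read-out higher numbers stand for higher solubility and lower numbers for lower solubility), compound 1 `COc1cccc(CN2C(=O)c3c(C)nc(-c4nc(C)no4)c(N)c3C2=O)c1` gives < 5000 nM, which is a limit of the assay and not a number. Compound 2 `Cc1noc(-c2nc(C)c3c(c2N)C(=O)N(Cc2ccc(Cl)cn2)C3=O)n1` gives < 5000 nM, which is also a limit, so its position is known only as a limit. Compound 3 `Cc1noc(-c2nc(C)c3c(c2N)C(=O)N(Cc2ccncc2)C3=O)n1` carries pyridin-4-yl in place of 5-chloropyridin-2-yl on a saturated chain carbon bound to an amide-type nitrogen in a ring. For the measured compounds named here, the one measured step that changes the group at this place, a step that the two limits leave unreadable from compound 1 to compound 2, gives no size to carry over. Going by the values given here, the series so far offers only (the limit of < 5000 nM in this assay, at which 2 of the 2 values shown sit). No direction can be drawn from this, so no shift beyond the scatter is expected in this assay. The expected step is a step that the limit leaves unreadable from compound 2 to compound 3. For compound 3 the estimate is 3000 nM, with an expected range of 1000 nM to 9000 nM.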

Compound 3, solubility: 26400 nM
Compound 3: the middle estimate sits 8.8-fold (0.94 log units) below what was measured; measured number above the stated range.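

In this assay, this place on a saturated chain carbon bound to an amide-type nitrogen in a ring now gives a first readable change, with an at least 5.2-fold higher number from compound 2 to compound 3 (0.72 log units; beyond the scatter) for the swap to pyridin-4-yl. The swap from 3-methoxyphenyl also reads, with an at least 5.2-fold higher number from compound 1 to compound 3 (0.72 log units; beyond the scatter) on the same shared core, so a change at this place alone can lift the number beyond the scatter. The step from compound 1 to compound 2 cannot be read, and both sizes above are minimum sizes, as the two earlier values are limits and not numbers: the limit of < 5000 nM in this assay, at which 2 of the 3 values shown sit.

The swap to pyridin-4-yl removes the chlorine and changes the pyridine group in one step, and the compounds shown do not separate the two. On these data alone, how plain pyridin-2-yl or a morpholine at this place would read remains open.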